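The source may report more compounds than this note shows. Statements on the series, on what has been measured and on what is new or still open speak of the compounds shown alone.

Of the compounds shown here, three sharing one core have been measured in a functional assay on PC-3 cells (Homo sapiens) for inhibition, read by sulforhodamine B assay, with a stated time of 48 h, tested at 50 uM; on this read-out higher numbers stand for more inhibition of growth at the one concentration tested and lower numbers for less inhibition of growth. Compound 1 `O=C1C(=O)N(CCCCn2cc(COc3cc(=O)oc4ccccc34)nn2)c2ccc(Cl)cc21` gives 14%, compound 2 `O=C1C(=O)N(CCCn2cc(COc3cc(=O)oc4ccccc34)nn2)c2ccc(I)cc21` gives 14%, and compound 3 `O=C1C(=O)N(CCCCn2cc(COc3cc(=O)oc4ccccc34)nn2)c2ccc(Br)cc21` gives 13%. Among the measured compounds shown here, the only single-point step, a number 1 percentage points lower from compound 1 to compound 3 (within the scatter), lies within the scatter. Compound 2 thus stands level with compound 1 and within the scatter of compound 3, with no order among the three. Compound 4 `O=C1C(=O)N(CCCn2cc(COc3cc(=O)oc4ccccc34)nn2)c2ccccc21` differs from compound 2 by hydrogen in place of iodo on an aromatic carbon. For the measured compounds named here, no measured step removes a halogen entirely; the only related step, that from compound 1 to compound 3, was small. In this assay the expected step is a number 1 percentage points lower from compound 2 to compound 4 (within the scatter), none beyond the scatter. Compound 4 is therefore estimated at 13%, between 4% and 22%.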

Compound 4, percent growth inhibition at one concentration: 25%
Compound 4: the middle estimate sits 12 percentage points below what was measured, and the stated range ends below it.
By their numbers in this assay, from the lowest: compounds 3, 1 and 2 (each within the scatter of the next); then compound 4.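

In this assay, hydrogen in place of iodo on this aromatic carbon gives a number 11 percentage points higher from compound 2 to compound 4 (beyond the scatter), so the group at this position can move the growth inhibition. The exchange of one halogen for another, a number 1 percentage points lower from compound 1 to compound 3 (within the scatter), did not show this. Nothing measured here accounts for the step.

On these data alone, whether fluoro, methoxy or an amine on this carbon would stay level with compound 4 or fall back towards compound 2 remains open. So does whether a longer chain would keep the number of compound 4.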